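The compounds below may be only part of what the source reports. "The series", "measured", "known", "first", "only" and "open" are said of these compounds alone.

Measured so far:
- compound 1, `CN1C(=O)C2=C(C1=O)N(CC(=O)Nc1ccc(-c3ccccc3)nn1)CCC2`: 36 mL.min-1.g-1
- compound 2, `CN1C(=O)C2=C(C1=O)N(CC(=O)Nc1ccc(-c3cccnc3)cc1)CCC2`: 48 mL.min-1.g-1

In an ADME assay on microsomes from liver (Mus musculus) for metabolic stability (a higher number here means faster removal of the compound, a lower number slower removal), compound 1 gives 36 mL.min-1.g-1. Compound 2 gives 48 mL.min-1.g-1 in this assay. The two numbers lie within the usual scatter of each other; compound 1 is the one with the lower figure, and no ordering of the pair can be read from the data. Going by the values given here, compound 2 differs from compound 1 in more than one place, so the pair gives no single step to lean on.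

Compound 3, `Cc1ccc(-c2ccc(NC(=O)CN3CCCC4=C3C(=O)N(C)C4=O)nn2)cn1`, has not yet been measured in this assay. It differs from compound 1 by 6-methylpyridin-3-yl in place of phenyl on an aromatic carbon. There is no measured step for a change of this kind in the series, so the only footing is the value of compound 1 itself. The expectation is a step from compound 1 to compound 3 of a 1.1-fold lower number from compound 1 to compound 3 (0.05 log units; within the scatter), which is not expected to exceed the scatter in either direction. Compound 3 is therefore estimated at 32 mL.min-1.g-1, with a range from 15 mL.min-1.g-1 to 65 mL.min-1.g-1.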

Compound 3, intrinsic clearance in microsomes in the liver assay: 8 mL.min-1.g-1
Beside the measured number, compound 3's estimate is 4.0-fold (0.60 log units) above it; measured number below the stated range.
By their numbers in the liver assay, from the lowest: compound 3; then compounds 1 and 2 (each within the scatter of the next).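

Going by these compounds alone, in the liver assay, 6-methylpyridin-3-yl in place of phenyl on this aromatic carbon gives a 4.5-fold lower number from compound 1 to compound 3 (0.65 log units; beyond the scatter), a step beyond the scatter that the earlier compounds, which differ in more than one place, could not provide. In a physicochemical assay for solubility, measured as thermodynamic solubility, at pH 7.4 (on this read-out lower numbers stand for lower solubility and higher numbers for higher solubility), compound 1 gives 3.34 ug/mL and compound 3 gives 35.5 ug/mL. This single change therefore moves both read-outs, and the physicochemical assay shows an 11-fold higher number from compound 1 to compound 3 (1.03 log units; beyond the scatter).

The ring nitrogen and the methyl enter together, and the compounds shown do not tell which of them carries the two steps. A plain pyridinyl ring or a methyl-bearing phenyl ring at this position on the core of compound 1 would separate them.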